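The source may report more compounds than this note shows. Statements on the series, on what has been measured and on what is new or still open speak of the compounds shown alone.

In a functional assay on A549 cells (Homo sapiens) for inhibition, read by MTT assay, with a stated time of 96 h (on this read-out higher numbers stand for weaker inhibition of growth and lower numbers for stronger inhibition of growth), three compounds that share a core have been measured so far. Compound 1 `O=C(NCCCCCCSSCCCCCCNC(=O)c1cc(-c2ccncc2)n[nH]1)c1cc(-c2ccncc2)n[nH]1`, which carries that core twice, gives 6070 nM. Compound 2 `CC(C)C(=O)SCCCCCCNC(=O)c1cc(-c2ccncc2)n[nH]1` gives 16800 nM, and compound 3 `CCCC(=O)SCCCCCCNC(=O)c1cc(-c2ccncc2)n[nH]1` gives 15100 nM. Compound 3 therefore stands level with compound 2, within the scatter, and its number is higher than that of compound 1, a gap beyond the scatter.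

The next compound, compound 4 `CC(=O)SCCCCCCNC(=O)c1cc(-c2ccncc2)n[nH]1`, differs from compound 3 by one change: hydrogen in place of ethyl on a saturated chain carbon bound to a carbonyl carbon. This is hydrogen in place of ethyl on a saturated chain carbon bound to a carbonyl carbon, which turns propyl into methyl and propylcarbonyl into acetyl.

Among the compounds with values here, only one measured step bears on this change: a 1.1-fold lower number from compound 2 to compound 3 (0.05 log units; within the scatter), where propyl took the place of isopropyl on a carbonyl carbon. That step stayed within the scatter, but it does not shorten the chain as the new change does, so it is only a loose guide. No step beyond the scatter is expected in this assay, and neither direction is favoured.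

Compound 4 is estimated at 14000 nM, with an expected range of 7000 nM to 28000 nM. This estimate means an expected step of a 1.1-fold lower number from compound 3 to compound 4 (0.03 log units; within the scatter).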

Compound 4, concentration for 50% growth inhibition: 18000 nM
Compound 4: middle estimate off by 1.3-fold (0.11 log units), on the low side, and the stated range covers the measured number.
By their numbers in this assay, from the lowest: compound 1; then compounds 3, 2 and 4 (each within the scatter of the next).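

In this assay, hydrogen in place of ethyl on a saturated chain carbon bound to a carbonyl carbon gives a 1.2-fold higher number from compound 3 to compound 4 (0.08 log units; within the scatter), and replacing the isopropyl-bearing carbonyl with acetyl gives a 1.1-fold higher number from compound 2 to compound 4 (0.03 log units; within the scatter). The earlier compounds shown here compared only propyl and isopropyl, two groups of the same atom count, whereas this result shows that the group on the carbonyl can lose 2 heavy atoms and the number still stays within the scatter, so acetyl, propylcarbonyl and the isopropyl-bearing carbonyl all stand level at this position. Nothing measured here offers an explanation for this flat result.

The compounds shown leave open whether a much longer chain or a phenyl ring on the carbonyl, or an amine or carboxylic acid at the end of such a chain, would move the number beyond the scatter. They also leave open what a plain thiol, with hydrogen in place of acetyl on the sulfur, would give in this cell read-out.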